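Adding a Methoxy Group to Compound 1

A few compounds are considered here, and "the series" means these few. Any claim that something is new, unique, unknown or untested is made for them only; others in the source may bear on it.

Measured in a functional assay on SW-620 cells (Homo sapiens) for inhibition; a higher number here means a weaker inhibitor, a lower number a stronger inhibitor:
- compound 1 `COc1ccc(C2NN=C(c3cc(OC)c(OC)c(OC)c3)C2O)cc1`: 2670 nM
- compound 2 `COc1cc(C2=NNC(c3ccc(Cl)cc3)C2O)cc(OC)c1OC`: 8410 nM
- compound 3 `COc1cc(C2=NNC(c3ccc(F)cc3)C2O)cc(OC)c1OC`: 5850 nM

Compound 1 has the lowest number of the three, and its steps to both others lie beyond the scatter. Compound 4 `COc1ccc(C2NN=C(c3cc(OC)c(OC)c(OC)c3)C2O)cc1OC` differs from it by methoxy in place of hydrogen on an aromatic carbon, ortho to a methoxy group: methoxy in place of hydrogen on an aromatic carbon.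

Within the data shown here, no measured step adds a group at such a carbon, so the evidence is indirect. Chloro in place of methoxy gave a 3.1-fold higher number from compound 1 to compound 2 (0.50 log units; beyond the scatter), and fluoro in place of methoxy gave a 2.2-fold higher number from compound 1 to compound 3 (0.34 log units; beyond the scatter). The exchange of chloro for fluoro gave a 1.4-fold lower number from compound 2 to compound 3 (0.16 log units; within the scatter). These modest steps replace a methoxy group rather than add one, so they favour no direction in this assay and suggest only a limited size. The estimate amounts to a 1.1-fold higher number from compound 1 to compound 4 (0.05 log units; within the scatter), which is expected to stay within the scatter. Compound 4 is expected at 3000 nM, with an estimated range from 1300 nM to 7000 nM.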

Compound 4, half-maximal inhibitory concentration: 8630 nM
Estimate against measurement, compound 4: 2.9-fold (0.46 log units) below; measured number above the stated range.
By their numbers in this assay, from the lowest: compound 1; then compounds 3, 2 and 4 (each within the scatter of the next).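

In this assay, among these compounds, methoxy in place of hydrogen on an aromatic carbon, ortho to a methoxy group, gave a 3.2-fold higher number from compound 1 to compound 4 (0.51 log units; beyond the scatter) and thus the first direct reading of a group added at such a carbon. The earlier compounds shown here only exchanged one group for another, so they could not show that an added methoxy group, with nothing removed, moves the number towards a weaker inhibitor by a step beyond the scatter. The compounds shown offer no measured property that bears on this step.

As far as these compounds go, whether this carbon tolerates any added group is still open, as only methoxy has been seen there. A hydroxyl group, an amine or a methyl group at the same carbon could show whether the step belongs to methoxy itself or to substitution at this place.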